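Amide group swap in a level cytotoxicity series

A few compounds are considered here, and "the series" means these few. Any claim that something is new, unique, unknown or untested is made for them only; others in the source may bear on it.

In an ADME assay on HepG2 2.2.15 cells (Homo sapiens) for cytotoxicity, read by MTT assay, with stated times of 48 h and 9 days (on this read-out higher numbers stand for lower toxicity in this test and lower numbers for higher toxicity in this test), compound 1 (`COc1ccc(CNC(=O)/C=C/c2coc3cc(O)ccc3c2=O)cc1`) reads 718000 nM while compound 2 (`COc1ccc2c(=O)c(/C=C/C(=O)Nc3ccccc3Cl)coc2c1`) reads 1010000 nM and compound 3 (`COc1ccc2c(=O)c(/C=C/C(=O)Nc3cc(C)ccc3C)coc2c1`) reads 1100000 nM on the same scale. Compound 3 stands level with the other two: its gaps to both lie within the scatter, so the three numbers give no ranking.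

The next compound is compound 4 (`COc1ccc(NC(=O)/C=C/c2coc3cc(OC)ccc3c2=O)cc1`). The change is 4-methoxyphenyl in place of 2,5-dimethylphenyl on an amide-type nitrogen and the rest of the structure stays the same, with 4-methoxyphenyl in place of 2,5-dimethylphenyl on an amide-type nitrogen.

Among the measured compounds shown here, only one measured step bears on that nitrogen: a 1.1-fold higher number from compound 2 to compound 3 (0.04 log units; within the scatter) for 2,5-dimethylphenyl in place of 2-chlorophenyl. That step lies within the scatter. For the measured compounds named here, no measured compound carries 4-methoxyphenyl at this place, so the evidence for the new group is indirect and the range has to stay wide. Going by the values given here, with the step from compound 2 (a 1.1-fold higher number from compound 2 to compound 3 (0.04 log units; within the scatter)) as the only guide, no step beyond the scatter is expected in this assay and no direction is favoured. The estimated step is a 1.2-fold lower number from compound 3 to compound 4 (0.06 log units; within the scatter) and that size is expected to stay inside the scatter. Compound 4 is estimated at 950000 nM (450000 nM to 2000000 nM as the expected range).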

Compound 4, half-maximal cytotoxic concentration: 718000 nM
For compound 4 the middle estimate is 1.3-fold (0.12 log units) above the measured one; measured number inside the range.
By their numbers in this assay, from the lowest: compounds 1, 4, 2 and 3 (each within the scatter of the next).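

In this assay, the amide-type nitrogen now has three measured aryl groups, and 4-methoxyphenyl in place of 2,5-dimethylphenyl gives a 1.5-fold lower number from compound 3 to compound 4 (0.19 log units; within the scatter), while 4-methoxyphenyl in place of 2-chlorophenyl gives a 1.4-fold lower number from compound 2 to compound 4 (0.15 log units; within the scatter). Both steps lie within the scatter, so this place tolerates a group bringing an oxygen and a hydrogen-bond acceptor, which 2,5-dimethylphenyl lacks, without any separation on this read-out, and compounds 2, 3 and 4 cannot be ranked. No independent measurement is available to explain this level reading.

On these data alone, the three groups compared at this nitrogen are all substituted phenyl rings, so the effect of a non-aromatic group such as cyclohexyl, or of a phenyl ring carrying a carboxylic acid or an amine, remains open. As far as these compounds go, it also remains open whether any group at this place can move the number beyond the scatter, and whether the same level reading would hold with a different group on the shared core.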